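Aryl substituent series: compound 3 to compound 4

The compounds below may be only part of what the source reports. "The series", "measured", "known", "first", "only" and "open" are said of these compounds alone.

The compounds share one core. Compound 1 `N#CC1=C(N)OC(c2c[nH]c3ccccc23)=C(C#N)C1c1ccc(Br)cc1` carries 4-bromophenyl on the saturated ring carbon, compound 2 `COc1ccc(C2C(C#N)=C(N)OC(c3c[nH]c4ccccc34)=C2C#N)cc1OC` carries 3,4-dimethoxyphenyl and compound 3 `Cc1ccc(C2C(C#N)=C(N)OC(c3c[nH]c4ccccc34)=C2C#N)cc1` carries 4-methylphenyl. In a functional assay (on this read-out lower numbers stand for stronger inhibition and higher numbers for weaker inhibition), compound 1 gives 947 ug/mL and compound 2 gives 867 ug/mL. For compound 3 the assay reports only a limit, > 1000 ug/mL. Compound 3 thus stands at the limit of > 1000 ug/mL in this assay, at which 1 of the 3 values shown sits. The steps of a 1.1-fold lower number from compound 1 to compound 2 (0.04 log units; within the scatter), an at least 1.0-fold higher number from compound 1 to compound 3 (0.02 log units; that floor lies within the scatter) and an at least 1.1-fold higher number from compound 2 to compound 3 (0.06 log units; that floor lies within the scatter) all lie within the scatter, so the three measured compounds cannot be ordered against one another.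

Compound 4 `COc1ccc(C2C(C#N)=C(N)OC(c3c[nH]c4ccccc34)=C2C#N)cc1` differs from compound 3 by methoxy in place of methyl on an aromatic carbon. Going by the values given here, no measured step changes this group in this place; the nearest comparisons exchange the whole aryl group on the saturated ring carbon, a 1.1-fold lower number from compound 1 to compound 2 (0.04 log units; within the scatter) and an at least 1.1-fold higher number from compound 2 to compound 3 (0.06 log units; that floor lies within the scatter), and neither moved beyond the scatter. A methoxy group is already present in compound 2 without a shift in the number. The step of a number no higher from compound 3 to compound 4 (the limit leaves the size open) is therefore expected to stay within the scatter. Compound 4 is estimated at 1000 ug/mL with a range from 700 ug/mL to 1500 ug/mL, and a reported limit rather than a number is about as likely as not.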

Compound 4, half-maximal inhibitory concentration: 859 ug/mL
Beside the measured number, compound 4's estimate is 1.2-fold (0.07 log units) above it, within the range that was stated.
By their numbers in this assay, from the lowest: compounds 4, 2 and 1 (each within the scatter of the next). At a limit, above all of these: compound 3.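

In this assay, from the compounds shown here alone, the exchange at this aromatic carbon, para to a large group, now has a step of its own: an at least 1.1-fold lower number from compound 3 to compound 4 (0.06 log units; that floor lies within the scatter), and the size of that step remains open beyond its printed floor. The neighbouring comparisons give the same picture, with a 1.0-fold lower number from compound 2 to compound 4 (0.00 log units; within the scatter) for hydrogen in place of methoxy and a 1.1-fold lower number from compound 1 to compound 4 (0.04 log units; within the scatter) for methoxy in place of bromo, so neither the second methoxy of the 3,4-dimethoxyphenyl group nor the exchange of bromo for methoxy separates these compounds. Compound 3 still has only a limit and not a number, which leaves methyl as the one group here that cannot be placed against the others: the limit of > 1000 ug/mL in this assay, at which 1 of the 4 values shown sits.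

No step among the compounds shown lies beyond the scatter, so this aromatic carbon has no measured link between group and read-out. Going by these compounds, whether an amine, a carboxylic acid or a longer chain such as butoxy on this carbon would move the number beyond the scatter remains open, as does the effect of any change elsewhere on the shared core.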